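This account rests on a few compounds, and the source may have more. Where it says the series, first, only, none or still open, it means among the compounds named here.

Measured so far:
compound 1, `CNC(=O)C1=CC(C)(C)Oc2ccc(C#N)cc21`: 263 nM
compound 2, `CCCCNC(=O)C1=CC(C)(C)Oc2ccc([N+](=O)[O-])cc21`: 21.9 nM

Both numbers come from a functional assay (muscle tissue) with Rattus norvegicus as the target; a higher number here means that more compound is needed for the effect, a lower number that less compound is needed. Compound 2 holds the lowest of the two values; its nearest neighbour is compound 1, whose number is higher, and the gap between them lies beyond the scatter. Going by the values given here, no single-point step between these two compounds is charted, so only the two values themselves are compared here, and the weight of the shared core cannot be separated from that of the side groups.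

Compound 3, `CC1(C)C=C(C(=O)NCCO)c2cc([N+](=O)[O-])ccc2O1`, is not yet measured in this assay. It derives from compound 2 by a single change: hydroxy in place of ethyl on a saturated chain carbon, two bonds along the chain from an amide-type nitrogen. Among the compounds with values here, nothing among the measured pair isolates this change, so its size is open. The expectation for compound 3 in this assay is a moderate rise in the number, somewhat beyond the scatter, rather than a large one.

For compound 3 the estimated value is 80 nM, with a range from 25 nM to 260 nM. This estimate corresponds to an expected step of a 3.7-fold higher number from compound 2 to compound 3 (0.56 log units; beyond the scatter).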

Compound 3, half-maximal effective concentration: 182 nM
Estimate against measurement, compound 3: 2.3-fold (0.36 log units) below; low and high end bracket the measured number.
By their numbers in this assay, from the lowest: compound 2; then compounds 3 and 1 (each within the scatter of the next).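

In this assay, the side chain on the amide proves sensitive to change: replacing ethyl with hydroxy on a saturated chain carbon, two bonds along the chain from an amide-type nitrogen, gives an 8.3-fold higher number from compound 2 to compound 3 (0.92 log units; beyond the scatter), a shift that the earlier pair could not isolate. The change removes ethyl and adds hydroxy in one move, so this pair cannot separate the loss of chain length from the gain of the hydroxy group. No measured property bears on this step, and the data offer no explanation for its size.

A plain propyl chain would help separate those two contributions, while a terminal methoxy, amine or carboxylic acid would show how far the outcome depends on the group that enters. Compound 1 differs from compound 2 and compound 3 in more than one place, so the role of the nitrile remains unresolved.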